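A few compounds are considered here, and "the series" means these few. Any claim that something is new, unique, unknown or untested is made for them only; others in the source may bear on it.

Working notes on the series. Of the compounds shown here, two so far carry values in an assay on cells for inhibition of S-adenosylmethionine decarboxylase proenzyme (Homo sapiens), read by mass spectrometry, at pH 7.2; a higher number here means a weaker inhibitor, a lower number a stronger inhibitor. Compound 1 `Cc1nc(N)cc(Nc2cc(Cl)cc(Br)c2)n1` is recorded there only as a limit, since in this assay compound 1 gives > 180000 nM. Compound 2 `Cc1cc(Nc2cc(Cl)cc(S(F)(F)(F)(F)F)c2)nc(N)n1` is recorded in the same way, as in this assay compound 2 gives > 180000 nM. Within the data shown here, both entries therefore sit at the limit of > 180000 nM in this assay, at which 2 of the 2 values shown sit; no numerical value exists for either, and no step between measured compounds can be drawn. Compound 2 thus stands at the limit, and nothing measured in the series distinguishes it from compound 1.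

Compound 3 `Cc1cc(Nc2cc(Br)cc(S(F)(F)(F)(F)F)c2)nc(N)n1` follows from compound 2 by bromo in place of chloro on an aromatic carbon. Among the measured compounds shown here, with compound 2 at the limit, no measured step exists to calibrate this change. The step from compound 2 to compound 3 is expected to be a step that the limit leaves unreadable from compound 2 to compound 3, that is none beyond the scatter, with a limit the most probable readout. In this assay compound 3 is estimated at 250000 nM, within a range of 100000 nM to 800000 nM.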

Compound 3, half-maximal inhibitory concentration: > 180000 nM
Compound 3: no number, only a limit (the forecaster's own chance of this, stated with the estimate: 85%); the middle value does not contradict the limit.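

In this assay compound 3 gives > 180000 nM, which is a limit and not a number. No step can be read between compound 2 and compound 3, as both rest on a limit: the limit of > 180000 nM in this assay, at which 3 of the 3 values shown sit. The compounds shown leave open how bromo and chloro compare here, and what numerical value any of these compounds would have.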